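The compounds below may be only part of what the source reports. "The series", "measured", "known", "first", "only" and "open" are said of these compounds alone.

Compound 1 `Cc1ccc(-c2cnn3c(NCc4ccccn4)cc(C)nc23)cc1` is the starting point. In a physicochemical assay for solubility, read by HPLC, using the shake flask method, measured as kinetic solubility, with a stated time of 2 h, at pH 7.4 (on this read-out lower numbers stand for lower solubility and higher numbers for higher solubility), compound 1 gives < 5000 nM, which is a limit of the assay rather than a number (the limit of < 5000 nM in this assay, at which 1 of the 3 values shown sits). Two further compounds share its core. Compound 2 `Cc1cc(NCc2ccccn2)n2ncc(Br)c2n1` gives 89300 nM in this assay, and compound 3 `Cc1cc(NCc2ncccn2)n2nc(C)c(-c3ccccc3)c2n1` gives 37900 nM. Going by the values given here, the only measured step that starts from compound 1 is an at least 17-fold higher number from compound 1 to compound 2 (1.25 log units; beyond the scatter); it shows how far the number can move when the aryl group is exchanged for a single atom, but it replaces the whole group and so bears only loosely on the change now in question. Compound 4 `Cc1cc(NCc2ccccn2)n2ncc(-c3ccc(C(F)(F)F)cc3)c2n1` differs from compound 1 by trifluoromethyl in place of methyl on an aromatic carbon. Among the compounds with values here, no measured step exchanges one substituent on that ring for another, so there is nothing among the measured compounds to set a direction or a size for this change. The expected step is therefore a step that the limit leaves unreadable from compound 1 to compound 4, a move not clearly beyond the scatter. Compound 4 is accordingly estimated at 3000 nM, with a range from 500 nM to 8000 nM, and it is thought likely that the assay again reports only a limit for it.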

Compound 4, solubility: < 5000 nM
Compound 4: a limit, no number; the forecaster's own chance of this, stated with the estimate: 70%; the middle value lies beyond the limit too.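

Compound 1 and compound 4 both sit at a limit of this assay rather than at a number, so the step between them cannot be read: the limit of < 5000 nM in this assay, at which 2 of the 4 values shown sit.

The compounds shown leave open whether trifluoromethyl in place of methyl moves the number at all, and if it does, in which direction and how far.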